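What to expect for compound 4

This account rests on a few compounds, and the source may have more. Where it says the series, first, only, none or still open, it means among the compounds named here.

compound 1 `COc1cc(NC(C)CCCNC(=O)NNC(=O)Nc2ccc(F)cc2)c2ncccc2c1` gives 310 nM
compound 2 `COc1cc(NC(C)CCCNC(=O)Nc2ccc(F)cc2)c2ncccc2c1` gives 26000 nM
compound 3 `COc1cc(NC(C)CCCNC(=O)NNC(=O)Nc2ccc(Br)cc2)c2ncccc2c1` gives 100 nM
compound 4 `COc1cc(NC(C)CCCNC(=O)Nc2cccc(O)c2)c2ncccc2c1` is not yet measured

In a functional assay on MCF7 cells (Homo sapiens) for inhibition, read by MTT assay, with a stated time of 72 h (a higher number here means a weaker inhibitor, a lower number a stronger inhibitor), compound 3 gives 100 nM as the lowest of the three numbers, and its gaps to the other two lie beyond the scatter. The move to compound 4 is a single change (3-hydroxyphenyl in place of ((4-bromophenyl)carbamoyl)amino on an amide-type nitrogen) in which 3-hydroxyphenyl replaces ((4-bromophenyl)carbamoyl)amino on an amide-type nitrogen. Compound 4 thus lacks the carbamoylamino link, as compound 2 does. Two large measured steps speak to that loss, since an 84-fold higher number from compound 1 to compound 2 (1.92 log units; beyond the scatter) and a 260-fold lower number from compound 2 to compound 3 (2.41 log units; beyond the scatter) each separate a compound with the link from one without it. Swapping the halogen alone gave a 3.1-fold lower number from compound 1 to compound 3 (0.49 log units; beyond the scatter) as a much smaller move. Going by the values given here, no measured compound carries 3-hydroxyphenyl, so the uncertainty is wide. A large move toward a weaker inhibitor is therefore expected, with a 100-fold higher number from compound 3 to compound 4 (2.00 log units; beyond the scatter) as the estimated step. The estimate for compound 4 is 10000 nM with 1500 nM to 50000 nM as the expected range.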

Compound 4, half-maximal inhibitory concentration: 11000 nM
Estimate against measurement, compound 4: 1.1-fold (0.04 log units) below, and the stated range covers the measured number.
By their numbers in this assay, from the lowest: compound 3; then compound 1; then compound 4; then compound 2.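

In this assay, replacing the ((4-bromophenyl)carbamoyl)amino group on the amide-type nitrogen with 3-hydroxyphenyl costs a great deal (a 110-fold higher number from compound 3 to compound 4 (2.04 log units; beyond the scatter)), and the same holds for the fluoro partner (a 35-fold higher number from compound 1 to compound 4 (1.55 log units; beyond the scatter)). Among the four compounds, the two with the carbamoylamino link now both give far lower numbers than the two without it, while changing the ring among the compounds lacking the link moves the number much less, though still beyond the scatter (a 2.4-fold lower number from compound 2 to compound 4 (0.37 log units; beyond the scatter)). Nothing measured here gives a reason for the size of these steps.

From the compounds shown here alone, it remains open how 3-hydroxyphenyl would behave on the carbamoylamino link, and how a ring carrying an amine or a carboxylic acid would compare. Going by these compounds, the effect of a longer chain in place of the link is also open.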